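Aryl Variation on a Fused Core: Antiproliferative Outlook

The source may hold more compounds than are shown below. What is called first, only, known or untested is meant among the compounds shown, and "the series" means these compounds.

Compound 1 `CCC1=C(O)c2c(oc(-c3ccc(C(F)(F)F)cc3)cc2=O)C(CC)(CC)C1=O`: 35.7 uM
Compound 2 `CCC1=C(O)c2c(oc(-c3ccc(F)cc3)cc2=O)C(CC)(CC)C1=O`: 33 uM
Compound 3 `CCC1=C(O)c2c(oc(-c3cc(Cl)c(OC)c(OC)c3)cc2=O)C(CC)(CC)C1=O`: 21.8 uM

Of the compounds shown here, three sharing one core have been measured in a functional assay on KB cells (Homo sapiens) for antiproliferative activity, read by sulforhodamine B assay, with a stated time of 3 days; on this read-out higher numbers stand for an effect only at larger amounts of compound and lower numbers for an effect already at smaller amounts. Compound 1 gives 35.7 uM. Compound 2 gives 33 uM. Compound 3 gives 21.8 uM. The number for compound 2 lies between those of compound 1 and compound 3, and its gap to each of them is within the usual scatter, so the three results are not distinguishable.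

Compound 4 `CCC1=C(O)c2c(oc(-c3cc(C)ccc3F)cc2=O)C(CC)(CC)C1=O` has not yet been measured. It differs from compound 2 in one place: 2-fluoro-5-methylphenyl in place of 4-fluorophenyl on an aromatic carbon. For the measured compounds named here, the only measured step that bears on this change alters the same aryl group, and it gave a 1.1-fold lower number from compound 1 to compound 2 (0.03 log units; within the scatter). Compound 3, which also carries a different aryl group, shows a number close to that of compound 2. On this basis no step beyond the scatter is expected.

Compound 4 is therefore estimated to give 33 uM, with a range from 15 uM to 70 uM. This estimate corresponds to an expected step of no change at the digits printed from compound 2 to compound 4 (within the scatter).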

Compound 4, concentration for half-maximal effect: 47.3 uM
Compound 4: the middle estimate sits 1.4-fold (0.16 log units) below what was measured; the range from low to high includes it.
By their numbers in this assay, from the lowest: compounds 3, 2, 1 and 4 (each within the scatter of the next, the first and the last beyond it).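

In this assay, 2-fluoro-5-methylphenyl in place of 4-fluorophenyl on the aromatic carbon next to the ring oxygen gives a 1.4-fold higher number from compound 2 to compound 4 (0.16 log units; within the scatter). The earlier step exchanged only trifluoromethyl for fluoro, whereas this one adds a methyl group and rearranges the groups on the aryl ring, and it still leaves compound 4 indistinguishable from compound 2. Nothing available explains the value of compound 4 or links it to any feature of the new group.

All the compounds shown carry a substituted phenyl group at this position, so it remains open whether an amine or a carboxylic acid on that ring would move the number beyond the scatter. Also open, as far as these compounds go, is what a pyridine ring or a longer alkyl chain in place of the phenyl group would do.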